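Urea-chain extension on an aminophenyl alcohol series

The source may hold more compounds than are shown below. What is called first, only, known or untested is meant among the compounds shown, and "the series" means these compounds.

Compound 1 `CCNC(=O)NCCC(O)c1ccccc1N` gives 18.3% in an assay for inhibition of Nitric oxide synthase, inducible (Homo sapiens), read by scintillation counting, with a stated time of 30 min, tested at 1 mM; on this read-out lower numbers stand for less inhibition and higher numbers for more inhibition at the one concentration tested (going by the name of the read-out). Compound 2 `CCCNC(=O)NCCC(O)c1ccccc1N` gives 19% in this assay; the difference from compound 1 is methyl in place of hydrogen on a saturated chain carbon, two bonds along the chain from an amide-type nitrogen, and the step is a number 0.7 percentage points higher from compound 1 to compound 2 (within the scatter). Compound 3 `CCNC(=O)NCCC(O)c1cc(OC)ccc1N` gives 26.6% in this assay; its core differs from that of compound 1 by methoxy in place of hydrogen on an aromatic carbon, and the step is a number 8.3 percentage points higher from compound 1 to compound 3 (within the scatter). All three values sit within the scatter of one another, so no ordering among compounds 1, 2 and 3 is claimed.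

Compound 4 `CCCNC(=O)NCCC(O)c1cc(OC)ccc1N` is not yet measured. It differs from compound 3 by methyl in place of hydrogen on a saturated chain carbon, two bonds along the chain from an amide-type nitrogen, the same change as from compound 1 to compound 2, at the same place. Beside the earlier step of a number 0.7 percentage points higher from compound 1 to compound 2 (within the scatter), the expected step is a number 0.4 percentage points higher from compound 3 to compound 4 (within the scatter), resting on that single precedent. Compound 4 is therefore estimated at 27% in this assay, with a range from 15% to 40% reflecting the scatter of this kind of measurement.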

Compound 4, a percentage reported as inhibition, at one concentration (the size of the read-out at that concentration, not a potency): 14.7%
Compound 4: middle estimate off by 12.3 percentage points, on the high side, outside the stated range (below it).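

Carried onto the methoxy-bearing core, the change from ethyl to propyl gives a number 11.9 percentage points lower from compound 3 to compound 4 (beyond the scatter) in this assay, and set against its single precedent the step does not separate from it: the same change on two cores in this assay, a number 0.7 percentage points higher (within the scatter) from compound 1 to compound 2 and a number 11.9 percentage points lower (beyond the scatter) from compound 3 to compound 4, 12.6 percentage points apart, within the scatter of two such steps
Read the other way round the square, the methoxy change on the propyl side gives a number 4.3 percentage points lower from compound 2 to compound 4 (within the scatter), and this likewise does not separate from its counterpart: the same change on two cores in this assay, a number 8.3 percentage points higher (within the scatter) from compound 1 to compound 3 and a number 4.3 percentage points lower (within the scatter) from compound 2 to compound 4, 12.6 percentage points apart, within the scatter of two such steps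
The chain change is therefore not shown to depend on the core, nor shown to carry over unchanged, and one pair of cores cannot settle either reading.

Open, on these data alone, is whether a longer chain such as butyl on the urea would shift the number beyond the scatter. The same holds for a fluorine or a hydroxyl in place of the methoxy.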